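A few compounds are considered here, and "the series" means these few. Any claim that something is new, unique, unknown or untested is made for them only; others in the source may bear on it.

In a functional assay on HeLa cells (Homo sapiens) for cytotoxicity, read by MTT assay, with a stated time of 72 h (on this read-out lower numbers stand for stronger inhibition and higher numbers for weaker inhibition), compound 1 `O=c1cc(CSc2nc3ccccc3s2)oc2ccccc12` gives only a limit, > 25000 nM. In this assay compound 2 `O=c1cc(CSc2nc3ccccc3s2)oc2ccc(Cl)cc12` likewise gives only a limit, > 25000 nM. These two differ by hydrogen in place of chloro on an aromatic carbon, and the step from compound 2 to compound 1 comes out as a step that the two limits leave unreadable from compound 2 to compound 1. Compound 3 `Cc1nnc(SCc2cc(=O)c3cc(Cl)ccc3o2)o1` has a different core; how its core differs from that of compound 2 is not broken down here. In this assay compound 3 also gives only a limit, > 25000 nM. Going by the values given here, every value so far sits at the limit of > 25000 nM in this assay, at which 3 of the 3 values shown sit. Compound 4 `Cc1nnc(SCc2cc(=O)c3ccccc3o2)o1` differs from compound 3 by hydrogen in place of chloro on an aromatic carbon, the same change seen between compound 2 and compound 1. Because compound 3 sits at the limit of > 25000 nM in this assay, at which 3 of the 3 values shown sit, compound 4 is expected to stay there as well, with an estimate of 40000 nM and a likely range from 15000 nM to 120000 nM. The step from compound 3 to compound 4 is thus expected to be a step that the limit leaves unreadable from compound 3 to compound 4.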

Compound 4, half-maximal inhibitory concentration: > 25000 nM
Compound 4 ended at the assay's limit; the forecaster's own chance of this, stated with the estimate: 85%; the middle value lies beyond the limit too.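

Compound 3 and compound 4 both end at a limit, so no step can be read between them: the limit of > 25000 nM in this assay, at which 4 of the 4 values shown sit.

The compounds shown leave open whether hydrogen in place of chloro changes cytotoxicity at all in this assay.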